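Amide for Ester on a Sugar-Bearing Pyrazole

This account rests on a few compounds, and the source may have more. Where it says the series, first, only, none or still open, it means among the compounds named here.

Measured compounds:
- compound 1, `CCOC(=O)c1cc(CI)[nH]n1`: > 100 ug/mL in a functional assay on HeLa cells (Homo sapiens); a higher number here means that more compound is needed for the effect, a lower number that less compound is needed
- compound 2, `NC(=O)c1cc(CI)[nH]n1`: > 100 ug/mL in this assay
- compound 3, `CCOC(=O)c1cc(CCl)nn1C1O[C@@H](COC(C)=O)[C@H](OC(C)=O)[C@@H](OC(C)=O)[C@@H]1OC(C)=O`: 40 ug/mL in this assay

Compound 1 gives only a limit in this assay, and so does compound 2; neither value is a number. Among the compounds with values here, compound 3 is the one compound with a measured number, (the limit of > 100 ug/mL in this assay, at which 2 of the 3 values shown sit). The step that the two limits leave unreadable from compound 1 to compound 2 is therefore a step whose size cannot be read. The change it makes is amino in place of ethoxy on a carbonyl carbon.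

Compound 4 is `CC(=O)OC[C@@H]1OC(n2nc(CCl)cc2C(N)=O)[C@@H](OC(C)=O)[C@H](OC(C)=O)[C@H]1OC(C)=O` and has not yet been measured in this assay. It is related to compound 3 by amino in place of ethoxy on a carbonyl carbon, the same change as from compound 1 to compound 2, made at a place described in the same words. The difference between the core of compound 1 and the core of compound 3 is not broken down here.

Within the data shown here, the only measured instance of this change sits between two limits, so it gives no guide to the size of the step. With that in mind, compound 4 is expected to stay close to compound 3, whose value is 40 ug/mL, and the step of a 1.3-fold higher number from compound 3 to compound 4 (0.10 log units; within the scatter) is an estimate rather than a measurement. The expected value for compound 4 is 50 ug/mL, with a range from 15 ug/mL to 150 ug/mL.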

Compound 4, concentration for half-maximal effect: 18 ug/mL
Beside the measured number, compound 4's estimate is 2.8-fold (0.44 log units) above it, within the range that was stated.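

On the core of compound 3, putting amino in place of ethoxy on a carbonyl carbon, which turns ethoxycarbonyl into carbamoyl, gives a 2.2-fold lower number from compound 3 to compound 4 (0.35 log units; beyond the scatter) in this assay; this is a modest step, but a real one, and a lower number here means that less compound is needed for the effect. The same change on the core of compound 1 is a step that cannot be read, as the values there are limits and not numbers: the limit of > 100 ug/mL in this assay, at which 2 of the 4 values shown sit.

The change has therefore been read on one core only, which shows that it can lower the number there but not that it carries over from one core to another, and a single pair of compounds cannot establish a trend or say why the number moved.

The compounds shown leave open whether another group on the same carbonyl carbon, such as a methylamino group or the hydroxyl of a free carboxylic acid, would shift the number further on the core of compound 3. They also leave open whether the step from ethoxycarbonyl to carbamoyl would be repeated on a third core, where both partners gave readable numbers.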